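The source may hold more compounds than are shown below. What is called first, only, known or untested is meant among the compounds shown, and "the series" means these compounds.

Going by the values given here, compound 2 `CCCCCCc1nc2nc(-c3ccccc3)cc(C(F)(F)F)c2c(=O)n1Cc1cn(CCC(F)(F)C(F)(F)C(F)(F)C(F)(F)C(F)(F)C(F)(F)F)nn1` is the only compound with a number in a functional assay on U-937 cells (Homo sapiens) for cytotoxicity, read by MTT assay, with a stated time of 24 h (a lower number here means a stronger inhibitor, a higher number a weaker inhibitor), where compound 2 gives 7.56 ug/mL. Compound 1 `O=c1c2c(C(F)(F)F)cc(-c3ccccc3)nc2ncn1Cc1cn(CCC(F)(F)C(F)(F)C(F)(F)C(F)(F)C(F)(F)C(F)(F)C(F)(F)C(F)(F)F)nn1` reaches only a limit in this assay, where compound 1 gives > 200 ug/mL, and this is the limit of > 200 ug/mL in this assay, at which 1 of the 2 values shown sits. Compound 3 `CCCCCCc1nc2nc(-c3ccccc3)cc(C(F)(F)F)c2c(=O)n1Cc1cn(CCC(F)(F)C(F)(F)C(F)(F)C(F)(F)C(F)(F)C(F)(F)C(F)(F)C(F)(F)F)nn1` differs from compound 2 by 1,1,2,2,2-pentafluoroethyl in place of fluoro on a saturated chain carbon bound to two fluorine atoms and a saturated chain carbon. Among the compounds with values here, no single step between measured compounds shows this change, so the step from compound 2 to compound 3 is expected to be small, a 1.3-fold higher number from compound 2 to compound 3 (0.12 log units; within the scatter), with no clear direction beyond the scatter. In this assay compound 3 is expected to give about 10 ug/mL, between 3 ug/mL and 40 ug/mL.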

Compound 3, half-maximal inhibitory concentration: > 200 ug/mL
Compound 3 ended at the assay's limit; the forecaster's own chance of this, stated with the estimate: 10%; middle value at least 20-fold (1.30 log units) from the limit.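

In this assay, replacing fluoro with 1,1,2,2,2-pentafluoroethyl on a saturated chain carbon bound to two fluorine atoms and a saturated chain carbon is not a small change, giving an at least 26-fold higher number from compound 2 to compound 3 (1.42 log units; beyond the scatter). On these data alone, that step ends on a limit for compound 3, so its full size is unknown, and the step from compound 1 to compound 3 cannot be read. With hexyl kept, this change alone takes the value to the limit: the limit of > 200 ug/mL in this assay, at which 2 of the 3 values shown sit.

As far as these compounds go, it remains open whether a shorter fluorinated chain would give a lower number, and how butyl or an amine in place of hexyl would read.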